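The source may hold more compounds than are shown below. What is called first, only, known or untested is meant among the compounds shown, and "the series" means these compounds.

- Compound 1 `CCCCN1CCN(c2ccc(S(=O)(=O)Oc3cccc(OC)c3)cc2)C1=O`: 490 nM
- Compound 2 `CCCCN1CCN(c2ccc(S(=O)(=O)Oc3cccc(Br)c3)cc2)C1=O`: 85 nM
- Compound 3 `CCCCN1CCN(c2ccc(S(=O)(=O)Oc3cc(F)cc(F)c3)cc2)C1=O`: not yet measured

Within the data shown here, in a functional assay on MCF7 cells (Homo sapiens) for antiproliferative activity, read by sulforhodamine B assay, with a stated time of 48 h (on this read-out lower numbers stand for stronger inhibition and higher numbers for weaker inhibition), compound 2 has the lower of the two numbers so far, at 85 nM, while compound 1 gives 490 nM. These two compounds differ in one place, bromo in place of methoxy on an aromatic carbon, and the result is a 5.8-fold lower number from compound 1 to compound 2 (0.76 log units; beyond the scatter).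

Compound 3 changes the same aromatic group: 3,5-difluorophenyl in place of 3-bromophenyl on an oxygen. In words, this is 3,5-difluorophenyl in place of 3-bromophenyl on an oxygen whose other neighbour is the sulfonyl sulfur.

Among the measured compounds shown here, only one measured step bears on this change, a 5.8-fold lower number from compound 1 to compound 2 (0.76 log units; beyond the scatter). It shows that a swap in this group can move the number modestly. However, no compound with fluorine has been measured, so it offers only a rough guide. Compound 2 is the lower of just two values at 85 nM, so a modest rise in this assay is expected, of similar or smaller size than that one step.

The expected result is a 2.6-fold higher number from compound 2 to compound 3 (0.41 log units; beyond the scatter). Compound 3 is estimated at about 220 nM, with an expected range of 70 nM to 700 nM.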

Compound 3, half-maximal inhibitory concentration: 400 nM
The estimate for compound 3 lay 1.8-fold (0.26 log units) below the measured number; low and high end bracket the measured number.
By their numbers in this assay, from the lowest: compound 2; then compounds 3 and 1 (each within the scatter of the next).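

In this assay, the group on the oxygen whose other neighbour is the sulfonyl sulfur now has three members, and replacing 3-bromophenyl with 3,5-difluorophenyl gives a 4.7-fold higher number from compound 2 to compound 3 (0.67 log units; beyond the scatter) in the expected direction, so the low number of compound 2 does not carry over to this fluorine-bearing group. The other new comparison (a 1.2-fold lower number from compound 1 to compound 3 (0.09 log units; within the scatter)) shows that the 3-methoxyphenyl and 3,5-difluorophenyl groups cannot be told apart here, which leaves compound 2 as the only one of the three that stands apart from the others. Nothing shown explains what sets the bromo compound apart from the other two.

From the compounds shown here alone, it remains open whether the low number belongs to bromo specifically, or whether chloro or iodo in its place, or a trifluoromethyl or methyl group, would give a similar result. Going by these compounds, all three compounds also share the rest of the structure, so it is equally open how a longer chain or an amine elsewhere on the core would behave alongside the 3-bromophenyl group.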